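The source may hold more compounds than are shown below. What is called first, only, known or untested is meant among the compounds shown, and "the series" means these compounds.

Compound 1 `N#CC1=C(N)Oc2c(c3nc4ccccc4nc3c3ccccc23)C12C(=O)N(Cc1cnnn1-c1ccc(Cl)cc1)c1ccccc12` and compound 2 `N#CC1=C(N)Oc2c(c3nc4ccccc4nc3c3ccccc23)C12C(=O)N(Cc1cnnn1-c1ccc([N+](=O)[O-])cc1)c1ccccc12` share one core and differ in a single change, (chloro in place of nitro on an aromatic carbon). In an ADME assay on L02 cells (Homo sapiens) for antiproliferative activity, read by MTT assay, with a stated time of 48 h (on this read-out lower numbers stand for stronger inhibition and higher numbers for weaker inhibition), compound 2 reaches only a limit of the assay, > 50000 nM. Compound 1 likewise stops at a limit, > 50000 nM. The step that the two limits leave unreadable from compound 2 to compound 1 therefore cannot be read, because of the limit of > 50000 nM in this assay, at which 2 of the 3 values shown sit. Compound 3 `N#CC1=C(N)Oc2c(N)cc3nc4ccccc4nc3c2C12C(=O)N(Cc1cnnn1-c1ccc([N+](=O)[O-])cc1[N+](=O)[O-])c1ccccc12` has a different core; how it differs from compound 2 is not broken down here. In this assay, within the data shown here, compound 3 gives 22800 nM, the only number among the three measured compounds. Compound 4 `N#CC1=C(N)Oc2c(N)cc3nc4ccccc4nc3c2C12C(=O)N(Cc1cnnn1-c1ccc(Cl)cc1[N+](=O)[O-])c1ccccc12` is the unmeasured partner of compound 3, reached by the same kind of change, (chloro in place of nitro on an aromatic carbon); here the place is meta to a nitro group (3 heavy atoms) as well as para to a large group, whereas in compound 1 it is para to a large group only. Among the measured compounds shown here, since the one earlier step of this kind, a step that the two limits leave unreadable from compound 2 to compound 1, is unreadable, the expected step of a 1.1-fold higher number from compound 3 to compound 4 (0.04 log units; within the scatter) rests on compound 3 alone and is expected to be small. Compound 4 is estimated at 25000 nM, between 9000 nM and 60000 nM.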

Compound 4, half-maximal inhibitory concentration: > 50000 nM
Compound 4 gave a limit, no number; the forecaster's own chance of this, stated with the estimate: 35%; middle value at least 2.0-fold (0.30 log units) away from the limit.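

In this assay, chloro in place of nitro gives an at least 2.1-fold higher number from compound 3 to compound 4 (0.34 log units; beyond the scatter), so on the core of compound 3 this change weakens inhibition by more than the usual scatter, and the size printed is only a minimum. The same change on the other core, from compound 2 to compound 1, cannot be read, so this one step on one core shows neither that the change carries over to another core nor that it fails to. The comparison between the two cores stays closed because the values crowd at one end of the measurable range: the limit of > 50000 nM in this assay, at which 3 of the 4 values shown sit.

Open, as far as these compounds go, is whether a fluoro or a carboxylic acid in that same place on the core of compound 3 would keep a true number or also end at the limit. Also open, from the compounds shown here alone, is how the change would read on the core of compound 1, if that core carried a group giving a number rather than a limit.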